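This account rests on a few compounds, and the source may have more. Where it says the series, first, only, none or still open, it means among the compounds named here.

Working notes on the series. In a functional assay on UACC-257 cells (Homo sapiens) for cytotoxicity, read by sulforhodamine B assay, with a stated time of 48 h (on this read-out lower numbers stand for stronger inhibition of growth and higher numbers for weaker inhibition of growth), compound 1 `ClCc1ccc(Cn2cnc3c(Cl)ncnc32)cc1` gives 28800 nM, compound 2 `ClCc1ccccc1Cn1cnc2c(Cl)nc(Cl)nc21` gives 3890 nM, and compound 3 `ClCc1ccccc1Cn1cnc2c(Cl)ncnc21` gives 26300 nM. Compound 3 stands second highest of the three; compound 1 lies within the scatter of it, while a 6.8-fold higher number from compound 2 to compound 3 (0.83 log units; beyond the scatter) separates it from compound 2. Compound 4 `Nc1nc(Cl)c2ncn(Cc3ccccc3CCl)c2n1` differs from compound 3 by amino in place of hydrogen on an aromatic carbon. Among the measured compounds shown here, the only measured step, from compound 2 to compound 3, concerns a chloro group rather than an amino group, so it bears on this change only loosely; a shift of either direction cannot be excluded, and no step beyond the scatter is expected with confidence. Compound 4 is therefore estimated at 15000 nM (range 4000 nM to 50000 nM), an expected 1.8-fold lower number from compound 3 to compound 4 (0.24 log units; within the scatter) in this assay.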

Compound 4, concentration for total growth inhibition: 38000 nM
Compound 4: middle estimate off by 2.5-fold (0.40 log units), on the low side; the measured number falls inside the stated range.
By their numbers in this assay, from the lowest: compound 2; then compounds 3, 1 and 4 (each within the scatter of the next).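

In this assay, amino in place of hydrogen on the aromatic carbon between two ring nitrogen atoms leaves the number within the scatter (a 1.4-fold higher number from compound 3 to compound 4 (0.16 log units; within the scatter)). On the same carbon, amino in place of chloro gives a clear change (a 9.8-fold higher number from compound 2 to compound 4 (0.99 log units; beyond the scatter)), so among the three groups seen there, only the chloro group of compound 2 stands apart. No measured information on the cause of this is at hand. Other groups on this carbon, such as methoxy or methylamino, remain open. Also open, going by these compounds, is whether amino acts alike on the core of compound 1.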